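A few compounds are considered here, and "the series" means these few. Any claim that something is new, unique, unknown or untested is made for them only; others in the source may bear on it.

Measured so far:
Compound 1 `CCCN1CCN(CCNC(=O)n2c(=O)n(C3CC3)c3ccccc32)CC1` gives 8.2 nM in an assay on isolated protein (striatum) for binding affinity to 5-hydroxytryptamine receptor 4 (Cavia porcellus), read by radioligand binding; on this read-out lower numbers stand for stronger inhibition and higher numbers for weaker inhibition.
Compound 2 `CC(C)n1c(=O)n(C(=O)NCCN2CCN(C)CC2)c2ccccc21` gives 91.1 nM.
Compound 3 `CN1CCN(CCNC(=O)n2c(=O)n(C)c3ccccc32)CC1` gives 306 nM.

Compound 3 shows the highest number of the three: compound 2 comes nearest to it, and compound 1 lies furthest away. Compound 4 `CCn1c(=O)n(C(=O)NCCN2CCN(C)CC2)c2ccccc21` differs from compound 3 by methyl in place of hydrogen on a saturated chain carbon bound to an aromatic nitrogen; seen one bond further out, this reads methyl to ethyl. Among the measured compounds shown here, the one measured step that bears on it is a 3.4-fold higher number from compound 2 to compound 3 (0.53 log units; beyond the scatter), where a larger group on an aromatic nitrogen went with a lower number. Going from methyl to ethyl covers part of that way back, so compound 4 is expected to show a modest drop, about a 1.8-fold lower number from compound 3 to compound 4 (0.26 log units; within the scatter), possibly still inside the scatter. Compound 4 is therefore estimated at 170 nM, in the range 80 nM to 400 nM.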

Compound 4, inhibition constant: 75.4 nM
Beside the measured number, compound 4's estimate is 2.3-fold (0.35 log units) above it; the measured number lies below the stated range.
By their numbers in this assay, from the lowest: compound 1; then compounds 4 and 2 (each within the scatter of the next); then compound 3.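

Turning methyl into ethyl on the aromatic nitrogen, a change of one carbon, already gives a 4.1-fold lower number from compound 3 to compound 4 (0.61 log units; beyond the scatter), so at this position the gain does not need a group as large as isopropyl. Ethyl and isopropyl cannot be told apart here, with a 1.2-fold lower number from compound 2 to compound 4 (0.08 log units; within the scatter). Nothing available explains why this one carbon counts for so much. The compounds shown leave open whether a longer chain such as butyl, or a benzyl group, on this nitrogen would keep the number at this level or shift it.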